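The source may hold more compounds than are shown below. What is called first, only, known or untested is meant among the compounds shown, and "the series" means these compounds.

Compound 1 `CCN(Cc1ccc(OC)cc1)Cc1c(O)ccc2c(=O)cc(C)oc12` is the reference point of this short series. In a functional assay on SK-MEL-2 cells (Homo sapiens) for inhibition, read by sulforhodamine B assay, with a stated time of 72 h (on this read-out lower numbers stand for stronger inhibition and higher numbers for weaker inhibition), compound 1 gives 60.3 ug/mL. Compound 2 `COc1ccc(CN(Cc2ccc([N+](=O)[O-])cc2)Cc2c(O)ccc3c(=O)cc(C)oc23)cc1` differs from it in one place. In this assay compound 2 reaches only the limit of the assay, > 100 ug/mL, a limit and not a number. That standing rests on the limit of > 100 ug/mL in this assay, at which 1 of the 2 values shown sits, rather than on a measured value. The step of an at least 1.6-fold higher number from compound 1 to compound 2 (0.21 log units; that floor lies within the scatter) is therefore itself only a floor. Compound 3 `COc1ccc(CN(Cc2ccc3ccccc3c2)Cc2c(O)ccc3c(=O)cc(C)oc23)cc1` is not yet measured. It differs from compound 2 by naphthalen-2-yl in place of 4-nitrophenyl on a saturated chain carbon bound to an amine nitrogen. For the measured compounds named here, only the step from compound 1 to compound 2 bears on this change, since it touches the same saturated chain carbon bound to the amine nitrogen; it sets a floor and nothing more, and that floor lies within the scatter. Because compound 2 gives only a limit, the step from compound 2 to compound 3 cannot be anchored to a number on its starting side. The expected step is an at least 1.1-fold lower number from compound 2 to compound 3 (0.04 log units; that floor lies within the scatter), taken as no change beyond the scatter. Compound 3 is therefore expected to give 90 ug/mL, with a range from 30 ug/mL to 250 ug/mL.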

Compound 3, half-maximal inhibitory concentration: > 100 ug/mL
Compound 3 gave a limit, no number; the forecaster's own chance of this, stated with the estimate: 45%; middle value at least 1.1-fold (0.04 log units) away from the limit.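

In this assay compound 3 also reaches only a limit, > 100 ug/mL, and not a number. For the compounds shown here, the step between the two limits cannot be read, which leaves naphthalen-2-yl, made of carbon only, and 4-nitrophenyl, which carries nitrogen and oxygen, without any order on this saturated chain carbon bound to an amine nitrogen; the only readable step is an at least 1.6-fold higher number from compound 1 to compound 3 (0.21 log units; that floor lies within the scatter). What the new result adds is that a second, quite different group in place of methyl at this place also gives no number, and the picture here now rests largely on limits: the limit of > 100 ug/mL in this assay, at which 2 of the 3 values shown sit.

From the compounds shown here alone, whether any replacement of methyl at this place moves the result beyond the scatter stays open, since a floor within the scatter does not settle it. Also open, going by these compounds, is how a longer chain such as butyl, a plain benzyl group without the nitro group, or a group carrying a carboxylic acid or a second amine would read on this carbon.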